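A few compounds are considered here, and "the series" means these few. Any claim that something is new, unique, unknown or untested is made for them only; others in the source may bear on it.

Compound 1 `Cc1nc2ccccc2nc1OCC(=O)Nc1ccc(Cl)cc1` in a functional assay on K562 cells (Homo sapiens) for inhibition, read by MTT assay, with a stated time of 24 h; a higher number here means a weaker inhibitor, a lower number a stronger inhibitor: > 100000 nM
Compound 2 `Cc1ccc(C(=O)Nc2ccc(Cn3c(=O)c(C)nc4ccccc43)cc2)cc1` in this assay : > 100000 nM

Of the compounds shown here, two have been measured, and neither gave a number. Compound 1 sits at a limit of the assay, > 100000 nM. Compound 2 likewise sits at a limit, > 100000 nM. Where compound 2 stands is therefore only this: it shares the limit of > 100000 nM in this assay, at which 2 of the 2 values shown sit, with compound 1, and nothing places it above or below its partner.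

Compound 3 `Cc1nc2ccccc2n(Cc2ccc(NC(=O)c3ccc(Cl)cc3)cc2)c1=O` has not yet been measured. It differs from compound 2 by chloro in place of methyl on an aromatic carbon, para to a large group. Within the data shown here, no step between measured compounds of this kind has been recorded, so there is no measured precedent to draw on. Given that compound 2 reports only a limit, a step of a number no higher from compound 2 to compound 3 (the limit leaves the size open) is expected, meaning no change beyond the scatter. The estimate for compound 3 in this assay is accordingly 100000 nM, within a range of 30000 nM to 300000 nM, with a strong expectation that the assay will again report only a limit.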

Compound 3, half-maximal inhibitory concentration: > 100000 nM
Compound 3: a limit, no number; the forecaster's own chance of this, stated with the estimate: 85%; the middle value lies on the limit itself.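

Compound 3 gives > 100000 nM, which is a limit and not a number. No step from compound 2 to compound 3 can be read, because both compounds stop at the same limit: the limit of > 100000 nM in this assay, at which 3 of the 3 values shown sit.

The compounds shown leave open how strongly any of them inhibits in this assay, and whether chloro in place of methyl changes that at all.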